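Notes on the six-membered ring swap toward compound 4

This account rests on a few compounds, and the source may have more. Where it says the series, first, only, none or still open, it means among the compounds named here.

Measured compounds:
Compound 1, `Cc1nn(-c2nc(-c3ccc(Cl)c(Cl)c3)c(SC(C)C)s2)c(C(=O)O)c1Cc1ccccc1[N+](=O)[O-]`, in a functional assay on BJAB cells (Homo sapiens) for antiproliferative activity, with a stated time of 4 days (a higher number here means that more compound is needed for the effect, a lower number that less compound is needed), gives 20000 nM.
Compound 2, `COc1cncc(-c2c(C)nn(-c3nc(-c4ccc(Cl)c(Cl)c4)c(SC(C)C)s3)c2C(=O)O)c1`, in this assay gives 21000 nM.
Compound 3, `Cc1nn(-c2nc(-c3ccc(Cl)c(Cl)c3)c(SC(C)C)s2)c(C(=O)O)c1-c1cncc(C#N)c1`, in this assay gives 20000 nM.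

Compound 3 sits level with compound 1 at the digits read, the two together at the low end of the three numbers; compound 2 is the furthest from it, yet that gap is within the scatter. For the measured compounds named here, the steps so far all touch the same carbon of the shared core: a 1.1-fold higher number from compound 1 to compound 2 (0.02 log units; within the scatter), no change at the digits printed from compound 1 to compound 3 (within the scatter) and a 1.1-fold lower number from compound 2 to compound 3 (0.02 log units; within the scatter). None of them leaves the scatter, so this position has tolerated three quite different groups without a visible effect in this assay.

Compound 4, `CNc1cc(-c2c(C)nn(-c3nc(-c4ccc(Cl)c(Cl)c4)c(SC(C)C)s3)c2C(=O)O)ccn1`, continues the same exchange: 2-(methylamino)pyridin-4-yl in place of 5-cyanopyridin-3-yl on an aromatic carbon. The two steps that bear on it, from compound 1 to compound 3 and from compound 2 to compound 3, were flat, so no step beyond the scatter is expected in this assay in either direction. The expected step is no change at the digits printed from compound 3 to compound 4 (within the scatter). Compound 4 is therefore estimated at 20000 nM, within 8000 nM to 50000 nM.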

Compound 4, half-maximal effective concentration: 18000 nM
Compound 4: middle estimate off by 1.1-fold (0.05 log units), on the high side, and the stated range covers the measured number.
By their numbers in this assay, from the lowest: compounds 4, 1, 3 and 2 (each within the scatter of the next).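

In this assay this carbon stays flat even when a hydrogen-bond donor enters: 2-(methylamino)pyridin-4-yl has 1 hydrogen-bond donor and no triple bond, 5-cyanopyridin-3-yl has 0 hydrogen-bond donors and 1 triple bond, and the exchange gives a 1.1-fold lower number from compound 3 to compound 4 (0.05 log units; within the scatter) in this series. The new group also stays within the scatter of the other two, with a 1.2-fold lower number from compound 2 to compound 4 (0.07 log units; within the scatter) and with a 1.1-fold lower number from compound 1 to compound 4 (0.05 log units; within the scatter) as well, so all four groups on this carbon read alike. No measurement at hand accounts for this flatness.

From the compounds shown here alone, whether any group on this carbon can move the number stays open, and a piperazine or an aminoalkyl chain there would be a sharper probe than another substituted pyridine. Also open, going by these compounds, is what an amide in place of the carboxy group would do, since the carboxy group is common to all four compounds.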